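The source may report more compounds than this note shows. Statements on the series, on what has been measured and on what is new or still open speak of the compounds shown alone.

Working notes on the series.

Compound 1 `COc1ccc(CSc2nc(Cc3ccccc3Br)c(C)c(=O)[nH]2)cc1` gives 179000 nM in an ADME assay on MT4 cells (Homo sapiens) for cytotoxicity, read by MTT assay; a lower number here means that less compound is tolerated, a higher number that more compound is tolerated. Compound 2 `Cc1c(Cc2ccccc2Br)nc(SCc2ccc([N+](=O)[O-])cc2)[nH]c1=O` reaches only a limit of the assay in this assay, >= 246000 nM, and no number. Compound 3 `CCc1c(Cc2ccccc2Br)nc(SCc2ccc(OC)cc2)[nH]c1=O` gives 165000 nM in this assay, the lowest of the two numbers shown; its nearest neighbour is compound 1, and that gap of a 1.1-fold lower number from compound 1 to compound 3 (0.04 log units; within the scatter) is within the scatter, so no order between compounds 3 and 1 is claimed.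

Compound 4 `CCc1c(Cc2ccccc2Br)nc(SCc2ccc([N+](=O)[O-])cc2)[nH]c1=O` is not yet measured. It differs from compound 3 in one place: nitro in place of methoxy on an aromatic carbon. The same change is already on record once, an at least 1.3-fold higher number from compound 1 to compound 2 (0.13 log units; that floor lies within the scatter), where the result was only a limit of the assay, as noted for compound 2 (the limit of >= 246000 nM in this assay, at which 1 of the 3 values shown sits).

On that basis the step is expected to be small or, at most, a modest rise that may again end in a limit; a shift beyond the scatter is not expected. The estimated step from compound 3 to compound 4 is a 1.3-fold higher number from compound 3 to compound 4 (0.12 log units; within the scatter). Compound 4 is therefore estimated at 220000 nM in this assay, in the range 130000 nM to 400000 nM, with a fair chance that only a limit is reported.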

Compound 4, half-maximal cytotoxic concentration: > 272000 nM
Compound 4: a limit, no number; the forecaster's own chance of this, stated with the estimate: 40%; middle value at least 1.2-fold (0.09 log units) from the limit.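

In this assay compound 4 gives > 272000 nM, a limit of the assay and not a number, so the 4-nitrophenyl group ends in a limit on the core of compound 3 as it did on the core of compound 1. The step from methoxy to nitro on this aromatic carbon therefore reads only as a floor, and that floor does not leave the scatter: an at least 1.6-fold higher number from compound 3 to compound 4 (0.21 log units; that floor lies within the scatter). The change is now on record on two cores rather than one, though neither record gives its full size: the same change on two cores in this assay, an at least 1.3-fold higher number (0.13 log units; that floor lies within the scatter) from compound 1 to compound 2 and an at least 1.6-fold higher number (0.21 log units; that floor lies within the scatter) from compound 3 to compound 4; the limit leaves it open whether they differ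

On these data alone, compound 2 and compound 4 both stand as limits, so the step between them cannot be read, and the effect of the added methyl on the nitro compounds stays open. Also open, as far as these compounds go, are the true size of the nitro step and where an amine or a carboxylic acid on the same aromatic carbon would fall in this assay relative to compound 3, which gives 165000 nM.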